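A longer chain and a second methyl on the piperidine

A few compounds are considered here, and "the series" means these few. Any claim that something is new, unique, unknown or untested is made for them only; others in the source may bear on it.

Compound 1 `Cc1oc(-c2ccc(Cl)cc2)nc1CN1CCC(C(=O)NCCCN2C[C@H](C)C[C@H](C)C2)CC1`: > 635 10^-6 cm/s in a physicochemical assay for permeability, using PAMPA (on this read-out higher numbers stand for higher permeability and lower numbers for lower permeability), which is a limit of the assay rather than a number.
Compound 2 `Cc1ccccc1-c1nc(CN2CCC(C(=O)NCCCN3CCC(C)CC3)CC2)c(C)o1`: 425 10^-6 cm/s in this assay.
Compound 3 `Cc1oc(-c2c(Cl)cccc2Br)nc1CN1CCC(C(=O)NCCCN2C[C@H](C)C[C@H](C)C2)CC1`: "not determined" (no result reported) in this assay, so no result is given.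

Within the data shown here, compound 2 therefore stands as the only plain number in this assay: compound 1 sits at a limit, and compound 3 has no value at all. The limit for compound 1 is recorded as the limit of > 635 10^-6 cm/s in this assay, at which 1 of the 3 values shown sits.

Compound 4 `Cc1ccccc1-c1nc(CN2CCC(C(=O)NCCCCN3C[C@H](C)C[C@H](C)C3)CC2)c(C)o1` differs from compound 2 in one place: (3,5-dimethylpiperidin-1-yl)methyl in place of 4-methylpiperidin-1-yl on a saturated chain carbon, three bonds along the chain from an amide-type nitrogen. Among the measured compounds shown here, no step between two measured compounds is available, so the expected size of the step in this assay is not anchored by a measured pair. A change in permeability from compound 2 to compound 4 is expected to be modest, upward, and probably not far beyond the scatter of repeated measurements, as a 1.3-fold higher number from compound 2 to compound 4 (0.12 log units; within the scatter). Compound 4 is estimated at 560 10^-6 cm/s, with a likely range from 330 10^-6 cm/s to 900 10^-6 cm/s.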

Compound 4, apparent permeability: 288 10^-6 cm/s
Estimate against measurement, compound 4: 1.9-fold (0.29 log units) above; measured number below the stated range.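

In this assay, compounds 2 and 4 form the first pair shown that differs in one place, and the change gives a 1.5-fold lower number from compound 2 to compound 4 (0.17 log units; within the scatter). On a saturated chain carbon, three bonds along the chain from an amide-type nitrogen, the move from 2-(4-methylpiperidin-1-yl)ethyl to 3-(3,5-dimethylpiperidin-1-yl)propyl therefore leaves the read-out within the scatter. The chain and the ring substitution change together in this single step, and no measurement shown accounts for the result.

Going by these compounds, how a morpholine at the end of the chain, or a 4-methylpiperidin-1-yl group on the propyl chain, would read in this assay remains open. Compound 1 gives > 635 10^-6 cm/s, which is a limit of the assay and not a number.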